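The source may hold more compounds than are shown below. What is called first, only, known or untested is meant among the compounds shown, and "the series" means these compounds.

Of the compounds shown here, three have been measured in a functional assay on the whole organism (Tail, strain ICR) with Mus musculus as the target, in the tail flick test, with a stated time of 60 min, at a dose of 25 umol/kg by the oral route; on this read-out lower numbers stand for a weaker effect and higher numbers for a stronger effect at the one dose given. Compound 1, `NC(=O)CC[C@H](NC(=O)CN(c1ncnc2c1ncn2C1CCCCO1)C1CC1)C(=O)OCc1ccccc1`, gives 39.4% in this assay. Compound 2, `C[C@H](NC(=O)CN(c1nc(Cl)nc2[nH]cnc12)C1CC1)C(=O)OCc1ccccc1`, gives 64.3%, and compound 3, `C[C@@H](O)[C@H](NC(=O)CN(c1nc(Cl)nc2[nH]cnc12)C1CC1)C(=O)O`, gives 30.1%. Among these three numbers compound 1 stands second highest: its nearest neighbour is compound 3, whose value lies lower by an amount within the usual scatter, so the two cannot be ranked against each other, while compound 2 lies higher by an amount beyond the scatter.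

Compound 4, `CC(C)(C)OC(=O)NCCCC[C@H](NC(=O)CN(c1ncnc2c1ncn2C1CCCCO1)C1CC1)C(=O)OCc1ccccc1`, has not yet been measured. It differs from compound 1 in a single place: 2-((tert-butoxycarbonyl)amino)ethyl in place of carbamoyl on a saturated chain carbon, three bonds along the chain from an amide-type nitrogen and a carbonyl carbon. The shared core and the remaining substituents are unchanged.

Among the measured compounds shown here, no pair of measured compounds differs in only one place, so no step of comparable kind can be read from the existing numbers, and the two chloro-bearing compounds differ from compound 1 in several groups at once. The change from compound 1 to compound 4 is therefore expected to bring only a small step in this assay, most likely no larger than the usual scatter, with the direction uncertain and a slight lean to the lower side. Compound 4 is estimated to give 35% in this assay, within a range from 15% to 58%. This corresponds to an expected step of a number 4.4 percentage points lower from compound 1 to compound 4 (within the scatter).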

Compound 4, a percentage reported as activity, at one dose (the size of the read-out at that dose, not a potency): 32.7%
Estimate against measurement, compound 4: 2.3 percentage points above, within the range that was stated.
By their numbers in this assay, from the lowest: compounds 3, 4 and 1 (each within the scatter of the next); then compound 2.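

In this assay, among the compounds shown here, putting 2-((tert-butoxycarbonyl)amino)ethyl in place of carbamoyl on a saturated chain carbon, three bonds along the chain from an amide-type nitrogen and a carbonyl carbon, gives a number 6.7 percentage points lower from compound 1 to compound 4 (within the scatter), the first single-place comparison. The entering group has 10 heavy atoms against the 3 of carbamoyl, yet at this one dose the read-out does not separate the two compounds, so at this position the larger group brings no step beyond the scatter. No measurement of any other kind bears on this result, so it remains an observation without an explanation.

The compounds shown leave open whether a free amine or a carboxylic acid at the end of this chain, or a longer or shorter chain, would behave in the same way. Steps to compound 2 and compound 3 cannot be read, as each differs from compound 1 and compound 4 in several places, so it also remains open whether this exchange would give a similar result on a chloro-bearing compound.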